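The compounds below may be only part of what the source reports. "The series", "measured", "known", "first", "only" and "open" are said of these compounds alone.

Of the compounds shown here, two built on a shared core have been measured so far. In an assay on isolated protein for inhibition of sphingosine kinase 1 (Homo sapiens) (on this read-out lower numbers stand for stronger inhibition and higher numbers for weaker inhibition), compound 1 `CC[C@H](NC(=O)[C@H]1NCC[C@@H]1O)c1ccc(-c2noc(CCC3CCCC3)n2)cc1` gives 56 nM. Compound 2 `CCCCCCCCc1nc(-c2ccc(CNC(=O)[C@H]3NCC[C@@H]3O)cc2)no1` gives 86 nM in this assay; the two values sit within the scatter of each other, so nothing separates them. Compound 3 `CCCCCCCc1nc(-c2ccc([C@H](CC)NC(=O)[C@H]3NCC[C@@H]3O)cc2)no1` has not been measured. It differs from compound 1 in one place: pentyl in place of cyclopentyl on a saturated chain carbon, two bonds along the chain from an aromatic carbon. Going by the values given here, no measured pair shows a change of this kind, so the expected step of a 1.3-fold higher number from compound 1 to compound 3 (0.10 log units; within the scatter) is small, not beyond the scatter, and if anything toward a somewhat higher number. Compound 3 is therefore expected to give about 70 nM, in a range from 30 nM to 160 nM.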

Compound 3, half-maximal inhibitory concentration in the sphingosine kinase 1 assay: 30 nM
Compound 3: middle estimate off by 2.3-fold (0.37 log units), on the high side; the measured number falls inside the stated range.
By their numbers in the sphingosine kinase 1 assay, from the lowest: compounds 3, 1 and 2 (each within the scatter of the next, the first and the last beyond it).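

In the sphingosine kinase 1 assay, replacing cyclopentyl with pentyl on a saturated chain carbon, two bonds along the chain from an aromatic carbon, gives a 1.9-fold lower number from compound 1 to compound 3 (0.27 log units; within the scatter), so the closed ring is not required at this place to keep the number in this range. In a physicochemical assay for solubility, at pH 7.4 (on this read-out lower numbers stand for lower solubility and higher numbers for higher solubility), compound 1 gives 36 ug/mL and compound 3 gives 9 ug/mL. The same change carries a cost that the earlier compounds could not show in the physicochemical assay: the measured solubility of compound 1, 36 ug/mL, and of compound 3, 9 ug/mL, a 4.0-fold lower number (0.60 log units; beyond the scatter)

As far as these compounds go, whether a longer chain, or a pentyl chain ending in an amine or a carboxylic acid, would hold the number in the sphingosine kinase 1 assay while raising the number in the physicochemical assay remains open.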